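Replacing the phenol ring with a chlorophenyl ring

The source may hold more compounds than are shown below. What is called first, only, known or untested is meant among the compounds shown, and "the series" means these compounds.

Compound 2 `COc1cc(/C=N/n2c(-c3ccccc3)nn(C3O[C@@H](OC(C)=O)[C@H](OC(C)=O)[C@@H](OC(C)=O)[C@@H]3C(C)=O)c2=S)ccc1O` is one of two compounds examined in a functional assay on Bel-7402 cells (Homo sapiens) for antiproliferative activity, read by MTT assay, with a stated time of 24 h (on this read-out higher numbers stand for weaker inhibition and lower numbers for stronger inhibition), where compound 2 gives 8600 nM. Going by the values given here, its only companion is compound 1 `CC(=O)O[C@@H]1OC(n2nc(-c3ccccc3)n(/N=C/c3ccc(O)cc3)c2=S)[C@@H](C(C)=O)[C@H](OC(C)=O)[C@H]1OC(C)=O`, which in this assay gives 11300 nM. Compound 2 has the lower of the two numbers, but the gap a 1.3-fold lower number from compound 1 to compound 2 (0.12 log units; within the scatter) is within the scatter, so the two compounds cannot be told apart on these data.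

The unmeasured compound 3 `CC(=O)O[C@@H]1OC(n2nc(-c3ccccc3)n(/N=C/c3ccc(Cl)cc3)c2=S)[C@@H](C(C)=O)[C@H](OC(C)=O)[C@H]1OC(C)=O` differs from compound 2 by 4-chlorophenyl in place of 4-hydroxy-3-methoxyphenyl on a carbon with a double bond to nitrogen. Among the compounds with values here, the one measured step, a 1.3-fold lower number from compound 1 to compound 2 (0.12 log units; within the scatter), bears on this only indirectly: it altered a substituent on the same aromatic ring and produced no change beyond the scatter. Within the data shown here, no step in which the hydroxyl is removed or a chlorine introduced has been measured, so the direction of the present change cannot be read from the data. The author therefore expects a step of a 1.0-fold higher number from compound 2 to compound 3 (0.02 log units; within the scatter), none beyond the scatter, and estimates that compound 3 would give 9000 nM in this assay, within a range from 3500 nM to 25000 nM.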

Compound 3, half-maximal inhibitory concentration: 17400 nM
Beside the measured number, compound 3's estimate is 1.9-fold (0.29 log units) below it; the measured number falls inside the stated range.
By their numbers in this assay, from the lowest: compounds 2, 1 and 3 (each within the scatter of the next, the first and the last beyond it).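

In this assay, going by these compounds alone, 4-chlorophenyl in place of 4-hydroxy-3-methoxyphenyl, on a carbon with a double bond to nitrogen, gives a 2.0-fold higher number from compound 2 to compound 3 (0.31 log units; beyond the scatter) and is the first change at this position to pass the scatter, though only modestly. The earlier step on this ring stayed within the scatter, so this position now shows that its substituents can shift the number, and that the shift here runs towards weaker inhibition. The narrower exchange of chloro in place of hydroxy on an aromatic carbon gives a 1.5-fold higher number from compound 1 to compound 3 (0.19 log units; within the scatter) and stays within the scatter, so a visible gap appears only against compound 2, the compound that carries the methoxy group. Nothing in the data given here accounts for this step.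

The compounds shown do not separate the loss of the methoxy and hydroxy groups from the arrival of the chlorine, as each single exchange on the ring remains within the scatter and only the double change passes it. On these data alone, it also remains open how this assay would respond to an amine or a carboxylic acid on the same aromatic ring, or to a bromine in the place of the chlorine.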